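The source may hold more compounds than are shown below. What is called first, only, known or untested is meant among the compounds shown, and "the series" means these compounds.

Compound 3, `COc1ncnc2c1c(-c1ccoc1)cn2[C@@H]1O[C@H](CO)[C@@H](O)[C@H]1O`, is the starting point. In a functional assay on HL-60 cells (Homo sapiens) for antiproliferative activity, read by XTT assay, with a stated time of 72 h (a higher number here means a weaker inhibitor, a lower number a stronger inhibitor), compound 3 gives 150 nM, the lowest of the two numbers recorded. Compound 1, `C#Cc1cn([C@@H]2O[C@H](CO)[C@@H](O)[C@H]2O)c2ncnc(N(C)C)c12`, carries a dimethylamino group on the shared core and gives 290 nM in this assay, a value within the scatter of the number for compound 3. Compound 2, `CNc1ncnc2c1c(-c1ccoc1)cn2[C@@H]1O[C@H](CO)[C@@H](O)[C@H]1O`, carries a methylamino group and reaches only a limit of this assay, > 15000 nM, so no number is known for it.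

Compound 4, `CN(C)c1ncnc2c1c(-c1ccoc1)cn2[C@@H]1O[C@H](CO)[C@@H](O)[C@H]1O`, is not yet measured. It differs from compound 3 in one place: dimethylamino in place of methoxy on an aromatic carbon. Among the measured compounds shown here, the only measured step at this position is the exchange of methylamino for methoxy, an at least 100-fold lower number from compound 2 to compound 3 (2.00 log units; beyond the scatter), where the one value that is a limit, (the limit of > 15000 nM in this assay, at which 1 of the 3 values shown sits), belongs to the methylamino compound. That step says little about dimethylamino, which carries no hydrogen-bond donor. Compound 1 shows that a dimethylamino group on this core can give a number close to that of compound 3. For the measured compounds named here, no step between compound 1 and compound 3 or compound 4 is recorded; a second group differs as well. The expectation for compound 4 is therefore a small step, a 2.0-fold higher number from compound 3 to compound 4 (0.30 log units; within the scatter), toward a somewhat higher number. Compound 4 is estimated at 300 nM, with a likely range from 100 nM to 1500 nM.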

Compound 4, half-maximal inhibitory concentration: 1160 nM
For compound 4 the middle estimate is 3.9-fold (0.59 log units) below the measured one, and the stated range covers the measured number.
By their numbers in this assay, from the lowest: compounds 3 and 1 (each within the scatter of the next); then compound 4. At a limit, above all of these: compound 2.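

In this assay, methoxy and dimethylamino each count no hydrogen-bond donors, yet exchanging one for the other on this aromatic carbon gives a 7.7-fold higher number from compound 3 to compound 4 (0.89 log units; beyond the scatter), so the donor count alone does not settle what this position tolerates. Placing a methyl on the nitrogen in place of hydrogen gives an at least 12-fold lower number from compound 2 to compound 4 (1.11 log units; beyond the scatter), which shows that a single methyl on this nitrogen changes the number by a large step, although the value for compound 2 is a limit and not a number: the limit of > 15000 nM in this assay, at which 1 of the 4 values shown sits. Furan-3-yl in place of ethynyl gives a 4.0-fold higher number from compound 1 to compound 4 (0.60 log units; beyond the scatter), so the number of compound 1 does not carry over to a compound with the same dimethylamino group, and the group on the other aromatic carbon also counts.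

The compounds shown leave open how an unsubstituted amine, an ethoxy group or a chlorine would behave at this position. They also leave open what the pairing of methoxy with ethynyl would give, which would show whether the effect of exchanging methoxy for dimethylamino holds with a different neighbouring group.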